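A few compounds are considered here, and "the series" means these few. Any claim that something is new, unique, unknown or untested is made for them only; others in the source may bear on it.

Compound 1 `O=C(NO)c1ccc(/C=C/c2ccnc(-c3cccc(O)c3)c2)cc1`: 2100 nM
Compound 2 `Cc1ccc(-c2cc(/C=C/c3ccc(C(=O)NO)cc3)ccn2)cc1`: 1910 nM
Compound 3 `COc1ccc(-c2cc(/C=C/c3ccc(C(=O)NO)cc3)ccn2)cc1`: 3510 nM

All three values come from a functional assay on MGC-803 cells (Homo sapiens) for antiproliferative activity, read by CellTiter-Glo, with a stated time of 72 h; on this read-out higher numbers stand for weaker inhibition and lower numbers for stronger inhibition. In this small set, compound 3 at 3510 nM cannot be separated from its two neighbours, as the steps show: a 1.7-fold higher number from compound 1 to compound 3 (0.22 log units; within the scatter), and a 1.8-fold higher number from compound 2 to compound 3 (0.26 log units; within the scatter). Among the measured compounds shown here, the remaining step, a 1.1-fold lower number from compound 1 to compound 2 (0.04 log units; within the scatter), is no larger in effect, so nothing measured so far stands clear of the noise.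

The next compound is compound 4 `Cc1ccc(-c2cc(/C=C/c3ccc(C(=O)NO)cc3)ccn2)c(F)c1`. It swaps 2-fluoro-4-methylphenyl in place of 4-methoxyphenyl, on the aromatic carbon next to the ring nitrogen: 2-fluoro-4-methylphenyl in place of 4-methoxyphenyl on an aromatic carbon.

The closest guide is the methoxy-for-methyl change, which gave a 1.8-fold higher number from compound 2 to compound 3 (0.26 log units; within the scatter). Compound 4 has a methyl on its ring again, so part of that small step may be undone, giving a slightly lower number. For the measured compounds named here, the fluoro group has no measured precedent here, so the data cannot say what it adds, and the range must stay wide.

The expected change is small, with no step beyond the scatter: a 1.8-fold lower number from compound 3 to compound 4 (0.24 log units; within the scatter). For compound 4 the estimated value is 2000 nM, with an expected range from 800 nM to 4500 nM.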

Compound 4, half-maximal inhibitory concentration: 770 nM
Beside the measured number, compound 4's estimate is 2.6-fold (0.41 log units) above it; the measured number lies below the stated range.
By their numbers in this assay, from the lowest: compound 4; then compounds 2, 1 and 3 (each within the scatter of the next).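

In this assay, the group on the aromatic carbon next to the ring nitrogen now proves able to move the number beyond the scatter, something no swap among the earlier groups did: 2-fluoro-4-methylphenyl in place of 4-methoxyphenyl gives a step described as (a 4.6-fold lower number from compound 3 to compound 4 (0.66 log units; beyond the scatter)), and in place of 3-hydroxyphenyl it gives (a 2.7-fold lower number from compound 1 to compound 4 (0.44 log units; beyond the scatter)). The cleanest reading comes from the pair that differs by one atom, where fluoro in place of hydrogen on the ring gives (a 2.5-fold lower number from compound 2 to compound 4 (0.39 log units; beyond the scatter)), so a single fluoro added to the 4-methylphenyl group is enough for a modest step. Nothing among the measurements available here explains why the fluoro has this effect.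

The compounds shown leave open whether a chlorine atom or a trifluoromethyl group on this ring would give a similar step, and whether fluoro would do the same on the 4-methoxyphenyl or 3-hydroxyphenyl groups. As far as these compounds go, it also remains open how the number would respond to an amine or a carboxylic acid on this ring, as a single fluoro example cannot yet mark out a trend.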